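A few compounds are considered here, and "the series" means these few. Any claim that something is new, unique, unknown or untested is made for them only; others in the source may bear on it.

In an ADME assay on L02 cells (Homo sapiens) for cytotoxicity, read by MTT assay, with a stated time of 24 h (on this read-out lower numbers stand for stronger inhibition and higher numbers for weaker inhibition), compound 2 (`O=C1/C(=C/c2cccc([N+](=O)[O-])c2)CN(S(=O)(=O)c2ccc(F)cc2)C/C1=C\c1ccccc1F`) gives 17000 nM and compound 1 (`N#Cc1ccc(/C=C2\CN(S(=O)(=O)c3ccc(F)cc3)C/C(=C\c3ccc(C#N)cc3)C2=O)cc1`) gives 18900 nM, two numbers within the usual scatter of each other. Compound 3 (`N#Cc1ccc(/C=C2\CN(S(=O)(=O)c3ccc(F)cc3)C/C(=C\c3ccccc3F)C2=O)cc1`) has 4-cyanophenyl in place of 3-nitrophenyl on a double-bonded chain carbon bound to a double-bonded ring carbon. Compound 1 also carries 4-cyanophenyl and gives 18900 nM, so no step beyond the scatter is expected in this assay. The estimated change is a 1.1-fold higher number from compound 2 to compound 3 (0.02 log units; within the scatter). For compound 3 the expected value is 18000 nM, with an estimated range of 9000 nM to 36000 nM.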

Compound 3, half-maximal inhibitory concentration: 21900 nM
The estimate for compound 3 lay 1.2-fold (0.09 log units) below the measured number; the range from low to high includes it.
By their numbers in this assay, from the lowest: compounds 2, 1 and 3 (each within the scatter of the next).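

In this assay, a change of group on a double-bonded chain carbon bound to a double-bonded ring carbon can now be read one place at a time, which compound 1 and compound 2 alone did not allow. 4-Cyanophenyl in place of 3-nitrophenyl gives a 1.3-fold higher number from compound 2 to compound 3 (0.11 log units; within the scatter), and 2-fluorophenyl in place of 4-cyanophenyl gives a 1.2-fold higher number from compound 1 to compound 3 (0.06 log units; within the scatter), so neither swap moves the number beyond the scatter. Nothing measured here offers an explanation for this. Still open, going by these compounds, is whether a group of another kind at this place, such as an amine or a carboxylic acid, would give a step beyond the scatter.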